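From 3-Fluorophenyl to 4-Methylphenyl on a Sulfur

The source may report more compounds than this note shows. Statements on the series, on what has been measured and on what is new or still open speak of the compounds shown alone.

In a functional assay on SMMC-7721 cells (Homo sapiens) for inhibition, read by CCK-8 assay, with a stated time of 72 h, tested at 8 uM (a higher number here means more inhibition of growth at the concentration tested, a lower number less inhibition of growth), compound 2 (`Nc1ccccc1NC(=O)/C=C/c1ccc(CSc2cccc(F)c2)cc1`) gives 8.25%. Compound 1 (`Nc1ccccc1NC(=O)/C=C/c1ccc(CSc2ccc(Cl)cc2)cc1`) gives 16.5%, within the scatter of compound 2, and together they form the low group among the three measured numbers. Compound 3 (`CCc1ccc(SCc2ccc(C(=O)Nc3ccccc3N)cc2)cc1`) stands apart at 82.9%, beyond the scatter of compound 2, but it differs from compound 2 in more than one place, so its number cannot be tied to any single change.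

Compound 4 (`Cc1ccc(SCc2ccc(/C=C/C(=O)Nc3ccccc3N)cc2)cc1`) has not yet been measured. It differs from compound 2 by 4-methylphenyl in place of 3-fluorophenyl on a sulfur, with 4-methylphenyl in place of 3-fluorophenyl on a sulfur. For the measured compounds named here, the only measured step at this place is a number 8.3 percentage points lower from compound 1 to compound 2 (within the scatter), and it stays within the scatter. With that step as the guide, no change beyond the scatter is expected in this assay. The estimated step is a number 7.8 percentage points higher from compound 2 to compound 4 (within the scatter). For compound 4 the expected value is 16%, with an estimated range from 3% to 42%.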

Compound 4, percent growth inhibition at one concentration: 22.2%
Estimate against measurement, compound 4: 6.2 percentage points below, and the stated range covers the measured number.
By their numbers in this assay, from the lowest: compounds 2, 1 and 4 (each within the scatter of the next, the first and the last beyond it); then compound 3.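

In this assay the group on the sulfur now gives its first step that the scatter does not cover: a number 14 percentage points higher from compound 2 to compound 4 (beyond the scatter) with 4-methylphenyl in place of 3-fluorophenyl. Methyl in place of chloro on an aromatic carbon gives a number 5.7 percentage points higher from compound 1 to compound 4 (within the scatter) and so does not separate the two compounds, which leaves compound 2, compound 1 and compound 4 as a chain in which only the two ends stand apart. Nothing at hand bears on what lies behind either step.

The compounds shown leave open whether 3-methylphenyl on the sulfur would read with 3-fluorophenyl or with 4-methylphenyl, since the step from compound 2 changes both the group and its place on the ring. As far as these compounds go, how 4-aminophenyl or 4-carboxyphenyl would read at this place also remains open.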